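Esters on a Shared Core: Heptyl Gives Way to Furanyl

This account rests on a few compounds, and the source may have more. Where it says the series, first, only, none or still open, it means among the compounds named here.

Two measured esters share one core. Compound 1 `CCCCCCCC(=O)OCc1cccc2c1CCOC2=O` carries a heptyl chain on the ester carbonyl. In an ADME assay on HepG2 2.2.15 cells (Homo sapiens) for cytotoxicity, read by MTT assay, with a stated time of 72 h (on this read-out lower numbers stand for higher toxicity in this test and higher numbers for lower toxicity in this test), compound 1 gives > 3450000 nM, which is a limit of the assay rather than a measured number, so compound 1 stands at the limit of > 3450000 nM in this assay, at which 1 of the 2 values shown sits. Compound 2 `O=C(O)c1ccccc1C(=O)OCc1cccc2c1CCOC2=O` is a second ester on the same core. In this assay compound 2 gives 130000 nM. The unmeasured compound 3 `O=C(OCc1cccc2c1CCOC2=O)c1ccco1` arises from compound 1 by one change: furan-2-yl in place of heptyl on a carbonyl carbon. Within the data shown here, no measured pair differs by this one change. For compound 3 the step of an at least 3.4-fold lower number from compound 1 to compound 3 (0.53 log units; beyond the scatter) is expected to be modest, leaning toward somewhat higher toxicity than the limit of compound 1 allows to be seen. Compound 3 is therefore estimated at about 1000000 nM, within an expected range from 200000 nM to 3450000 nM.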

Compound 3, half-maximal cytotoxic concentration: > 2350000 nM
Compound 3 ended at the assay's limit; the forecaster's own chance of this, stated with the estimate: 40%; middle value at least 2.3-fold (0.37 log units) away from the limit.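

Among these compounds, compound 1 and compound 3 both stand at limits of this assay rather than at measured numbers, so no step between them can be read. The compounds shown leave open whether furan-2-yl in place of heptyl on a carbonyl carbon changes the read-out in this assay at all.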